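The source may report more compounds than this note shows. Statements on the series, on what has been measured and on what is new or still open speak of the compounds shown alone.

Compound 1 `Oc1ccccc1-c1cc(-c2ccc(F)cc2)cc(-c2ccccc2O)n1`: in a functional assay on HCT-15 cells (Homo sapiens) for inhibition (on this read-out higher numbers stand for weaker inhibition and lower numbers for stronger inhibition), compound 1 gives > 50000 nM, which is a limit of the assay and not a number.
Compound 2 `Oc1cccc(-c2cc(-c3ccc(F)cc3)cc(-c3ccccc3O)n2)c1`: in this assay compound 2 gives > 50000 nM, again a limit.
Compound 3 `Oc1ccccc1-c1cc(-c2ccccc2C(F)(F)F)cc(-c2ccccc2O)n1`: in this assay compound 3 gives 3970 nM.

Compound 3 differs from compound 1 by 2-(trifluoromethyl)phenyl in place of 4-fluorophenyl on an aromatic carbon, and that change brings an at least 12-fold lower number from compound 1 to compound 3 (1.10 log units; beyond the scatter). Compound 2 differs from compound 1 by 3-hydroxyphenyl in place of 2-hydroxyphenyl on an aromatic carbon; this step is a step that the two limits leave unreadable from compound 1 to compound 2, since both values sit at the limit of > 50000 nM in this assay, at which 2 of the 3 values shown sit. Compound 4 `Oc1cccc(-c2cc(-c3ccccc3C(F)(F)F)cc(-c3ccccc3O)n2)c1` differs from compound 3 by 3-hydroxyphenyl in place of 2-hydroxyphenyl on an aromatic carbon. This is the same kind of change as from compound 1 to compound 2, but the surroundings differ: in compound 1 the place is meta to a 4-fluorophenyl group, in compound 3 it is meta to a 2-(trifluoromethyl)phenyl group. The earlier step has no readable size, so the expectation rests only on compound 3 and its value 3970 nM, with wide uncertainty. Compound 4 is expected to give 9000 nM in this assay, plausibly between 2500 nM and 40000 nM. The corresponding expected step is a 2.3-fold higher number from compound 3 to compound 4 (0.36 log units; beyond the scatter).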

Compound 4, half-maximal inhibitory concentration: 9010 nM
Estimate against measurement, compound 4: 1.0-fold (0.00 log units) below; the measured number falls inside the stated range.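

In this assay, 3-hydroxyphenyl in place of 2-hydroxyphenyl brings a 2.3-fold higher number from compound 3 to compound 4 (0.36 log units; beyond the scatter), whereas the same exchange on the core of compound 1 cannot be read, since both of its values are limits. 2-(Trifluoromethyl)phenyl in place of 4-fluorophenyl brings an at least 5.5-fold lower number from compound 2 to compound 4 (0.74 log units; beyond the scatter). That change therefore lowers the number on both cores, so its direction carries over in these two pairs, but its size cannot be compared: the same change on two cores in this assay, an at least 12-fold lower number (1.10 log units; beyond the scatter) from compound 1 to compound 3 and an at least 5.5-fold lower number (0.74 log units; beyond the scatter) from compound 2 to compound 4; the limit leaves it open whether they differ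

The compounds shown leave open how the number would move with an amine or a carboxylic acid in place of the hydroxyl group on these phenyl rings. They also leave open whether a 2-chlorophenyl group would give a step like that of 2-(trifluoromethyl)phenyl.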